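Formylmethyl against acetyl on the saturated side chain

The compounds below may be only part of what the source reports. "The series", "measured", "known", "first", "only" and "open" are said of these compounds alone.

compound 1 `COc1cccc(Sc2c(NS(=O)(=O)c3ccc(C(C)(C)C)cc3)noc2CCCCC=O)c1` — 20 nM
compound 2 `Cc1onc(NS(=O)(=O)c2ccc(C(C)(C)C)cc2)c1I` — 30000 nM

Both were measured in an assay on COS-7 cells for displacement of a labelled ligand from Endothelin receptor type B (Sus scrofa); a higher number here means a weaker inhibitor, a lower number a stronger inhibitor. Compound 1 holds the lowest of the two numbers; compound 2 sits far higher, a gap well beyond the scatter. Among the measured compounds shown here, no step between measured compounds differing in one place is available for this series. Compound 3 `COc1cccc(Sc2c(NS(=O)(=O)c3ccc(C(C)(C)C)cc3)noc2CCCC(C)=O)c1` differs from compound 1 in one respect only: acetyl in place of formylmethyl on a saturated chain carbon, three bonds along the chain from an aromatic carbon. For the measured compounds named here, with no measured precedent, a change near the scatter is expected in this assay, in either direction. For compound 3 the estimate is 30 nM, ranging from 8 nM to 120 nM. The expected step is a 1.5-fold higher number from compound 1 to compound 3 (0.18 log units; within the scatter).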

Compound 3, half-maximal inhibitory concentration: 400 nM
Compound 3: middle estimate off by 13-fold (1.12 log units), on the low side; the measured number lies above the stated range.
By their numbers in this assay, from the lowest: compound 1; then compound 3; then compound 2.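

In this assay the change from 4-formylbutyl to 3-acetylpropyl gives a 20-fold higher number from compound 1 to compound 3 (1.30 log units; beyond the scatter) with the same atoms and the same counts of heavy atoms, donors and acceptors. This place on the chain therefore responds to how those atoms are joined, not only to which atoms are present. Nothing available bears on the reason for this step.

The compounds shown leave open how a carboxylic acid, an amine or a longer chain at this place would compare with 4-formylbutyl. They also leave open whether the carbonyl is needed at all.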